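Side-chain change on the shared core: butyl to dimethylaminoethyl

This account rests on a few compounds, and the source may have more. Where it says the series, first, only, none or still open, it means among the compounds named here.

Measured so far:
compound 1 `CCCCNc1ccnc2cc(Cl)ccc12`, 6500 nM in a functional assay on MDA-MB-231 cells (Homo sapiens) for cytotoxicity, read by sulforhodamine B assay, with a stated time of 48 h, in the presence of a further agent that is not named here; a higher number here means a weaker inhibitor of growth, a lower number a stronger inhibitor of growth
compound 2 `CCCCNc1ccnc2cc(F)ccc12`, 3740 nM

Compound 1 gives the highest of the two numbers; its nearest neighbour is compound 2, with a 1.7-fold lower number from compound 1 to compound 2 (0.24 log units; within the scatter).

Compound 3 `CN(C)CCNc1ccnc2cc(Cl)ccc12` is unmeasured. It differs from compound 1 in one place: dimethylamino in place of ethyl on a saturated chain carbon, two bonds along the chain from a nitrogen on an aromatic ring.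

Going by the values given here, the single measured step concerns a halogen swap on the aromatic ring and does not bear on a change in the chain. Among the compounds with values here, no measured step speaks to this change, so the expectation is a number close to that of compound 1, with wide uncertainty. For compound 3 the estimate is 5000 nM, range 1500 nM to 15000 nM, which means an expected step of a 1.3-fold lower number from compound 1 to compound 3 (0.11 log units; within the scatter).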

Compound 3, concentration for 50% growth inhibition: 740 nM
For compound 3 the middle estimate is 6.8-fold (0.83 log units) above the measured one, and the stated range ends above it.
By their numbers in this assay, from the lowest: compound 3; then compounds 2 and 1 (each within the scatter of the next).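

Of the steps shown, only this change on the saturated chain goes beyond the scatter in this assay: butyl to 2-(dimethylamino)ethyl gives an 8.8-fold lower number from compound 1 to compound 3 (0.94 log units; beyond the scatter) (modest), whereas the halogen swap on the aromatic ring stays within it. The chain therefore responds to a change at this position, and the terminal dimethylamino group goes with the lower number in this chloro pair. No measurement shown accounts for the step.

Open, as far as these compounds go, is whether a longer chain ending in dimethylamino, or a pyrrolidine in place of dimethylamino, would keep this step. Also open, from the compounds shown here alone, is whether the same chain gives a similar step on the fluoro core of compound 2.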